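The source may report more compounds than this note shows. Statements on the series, on what has been measured and on what is new or still open speak of the compounds shown alone.

Measured so far in a functional assay on MDA-MB-231 cells (Homo sapiens) for antiproliferative activity, with a stated time of 72 h; a higher number here means a weaker inhibitor, a lower number a stronger inhibitor:
- compound 1 `COc1ccc(C2CC(c3ccccc3)=NN2c2nc(-c3ccccc3)c(C#N)c(=O)n2C)cc1` gives 12800 nM
- compound 2 `Cn1c(N2N=C(c3ccc(Cl)cc3)CC2c2ccccc2)nc(-c2ccccc2)c(C#N)c1=O` gives 10600 nM
- compound 3 `COc1ccc(C2CC(c3ccc(Cl)cc3)=NN2c2nc(-c3ccccc3)c(C#N)c(=O)n2C)cc1` gives 11100 nM

Compound 3 sits second highest of the three numbers, but its distance to both neighbours lies within the scatter: a 1.2-fold lower number from compound 1 to compound 3 (0.06 log units; within the scatter) and a 1.0-fold higher number from compound 2 to compound 3 (0.02 log units; within the scatter). The three compounds are therefore indistinguishable on these data.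

Compound 4 `COc1ccc(C2=NN(c3nc(-c4ccccc4)c(C#N)c(=O)n3C)C(c3ccc(OC)cc3)C2)cc1` differs from compound 3 by methoxy in place of chloro on an aromatic carbon. Both measured steps bear on it: putting chloro at that carbon, or methoxy at the other aryl, moved nothing beyond the scatter. Compound 4 is expected to stay in the same range, with a 1.1-fold higher number from compound 3 to compound 4 (0.03 log units; within the scatter) as the estimated step. Compound 4 is expected to give about 12000 nM in this assay, between 6000 nM and 24000 nM.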

Compound 4, half-maximal inhibitory concentration: 16200 nM
The estimate for compound 4 lay 1.4-fold (0.13 log units) below the measured number; the measured number falls inside the stated range.
By their numbers in this assay, from the lowest: compounds 2, 3, 1 and 4 (each within the scatter of the next).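

In this assay, the change from 4-chlorophenyl to 4-methoxyphenyl gives a 1.5-fold higher number from compound 3 to compound 4 (0.16 log units; within the scatter), and the change from phenyl to 4-methoxyphenyl gives a 1.3-fold higher number from compound 1 to compound 4 (0.10 log units; within the scatter). Hydrogen, chloro and methoxy at this carbon, para to a large group, are therefore not told apart. Methoxy in place of hydrogen also reads alike on two cores: the same change on two cores in this assay, a 1.0-fold higher number (0.02 log units; within the scatter) from compound 2 to compound 3 and a 1.3-fold higher number (0.10 log units; within the scatter) from compound 1 to compound 4, 1.2-fold (0.08 log units) apart, within the scatter of two such steps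

The compounds shown leave open whether an amine or a carboxylic acid on this carbon would move the number beyond the scatter. They also leave open whether any change at this carbon can do so.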